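From 2-methylbenzyl to 4-nitrobenzyl on the shared core

The source may report more compounds than this note shows. Statements on the series, on what has been measured and on what is new or still open speak of the compounds shown alone.

Measured in a functional assay on HUVEC cells (Homo sapiens) for antiproliferative activity, read by MTT assay, with a stated time of 24 h; a higher number here means a weaker inhibitor, a lower number a stronger inhibitor:
Compound 1 `COc1cc(OC)c(-c2coc3cc(OCc4ccc(F)cc4)ccc3c2=O)cc1OC`: > 10000 nM (a limit, not a number)
Compound 2 `COc1cc(OC)c(-c2coc3cc(OCc4ccccc4C)ccc3c2=O)cc1OC`: 4830 nM

Among the measured compounds shown here, compound 2, at 4830 nM, holds the only actual number in this assay so far. Compound 1 reached only a limit.

Compound 3 `COc1cc(OC)c(-c2coc3cc(OCc4ccc([N+](=O)[O-])cc4)ccc3c2=O)cc1OC` has yet to be measured. It carries 4-nitrophenyl in place of 2-methylphenyl on a saturated chain carbon bound to an oxygen on an aromatic ring.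

For the measured compounds named here, one measured step bears on this change: an at least 2.0-fold lower number from compound 1 to compound 2 (0.31 log units; beyond the scatter), where 2-methylphenyl replaced 4-fluorophenyl at the same place. Compound 3 gives up that same 2-methylphenyl for another group named at the 4 position, as in compound 1. A single step with a different group is thin support, but it points towards a higher number, of modest size, in this assay. The expected change is a 1.6-fold higher number from compound 2 to compound 3 (0.19 log units; within the scatter). For compound 3 the estimated value is 7500 nM, with an expected range of 2500 nM to 20000 nM.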

Compound 3, half-maximal inhibitory concentration: > 10000 nM
Compound 3: a limit, no number; the forecaster's own chance of this, stated with the estimate: 40%; at least 1.3-fold (0.12 log units) between middle value and limit.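

In this assay, among the compounds shown here, the move from 2-methylbenzyl to 4-nitrobenzyl gives an at least 2.0-fold higher number from compound 2 to compound 3 (0.31 log units; beyond the scatter), so this position now responds to the aryl group in a second pair as well as the first, and in both pairs the 2-methylphenyl compound is the one with the lower number. Among the compounds shown, 2-methylphenyl alone gives a measured number, while 4-fluorophenyl and 4-nitrophenyl both stop at the same limit: the limit of > 10000 nM in this assay, at which 2 of the 3 values shown sit. The change of nitro for fluoro between compound 1 and compound 3 cannot be read, as both of its ends are limits and neither is a number.

The compounds shown cannot separate the effect of the methyl group itself from that of where it sits on the ring, and they do not show how far compound 1 and compound 3 lie past their limits. From the compounds shown here alone, it also stays open whether an amine on that ring, or a longer chain between the oxygen and the ring, would shift the number of compound 2, 4830 nM, in either direction.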